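Phenethyloxy in Place of Benzylcarbamoyl on a Fused Lactam

A few compounds are considered here, and "the series" means these few. Any claim that something is new, unique, unknown or untested is made for them only; others in the source may bear on it.

Of the compounds shown here, three have been measured in a functional assay on HEK293 cells for agonist activity at G-protein coupled receptor 39 (Homo sapiens), read by scintillation proximity assay and inositol phosphate accumulation, with a stated time of 75 min, in the presence of a further agent that is not named here; on this read-out higher numbers stand for an effect only at larger amounts of compound and lower numbers for an effect already at smaller amounts. Compound 1 `C/C(=N\NC(=O)c1cc2ccccc2cc1O)c1ccc(N)cc1` gives 1100 nM in this assay. Compound 2 `Cc1cc(C)n(CCOC2CC(=O)Nc3c2c(C)nn3-c2ncnc3nc[nH]c23)n1` gives 16 nM in this assay, and compound 3 `Cc1nn(-c2ncnc3nc[nH]c23)c2c1C(C(=O)NCc1ccccc1)CC(=O)N2` gives 5 nM in this assay, the lowest of the three numbers, with compound 2 its nearest neighbour and compound 1 its furthest. For the measured compounds named here, the only step between compounds that differ in a single place is a 3.2-fold lower number from compound 2 to compound 3 (0.51 log units; beyond the scatter).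

Compound 4 `Cc1nn(-c2ncnc3nc[nH]c23)c2c1C(OCCc1ccccc1)CC(=O)N2` has not yet been measured. It differs from compound 3 in one place: phenethyloxy in place of benzylcarbamoyl on a saturated ring carbon. The step that bears on this change is a 3.2-fold lower number from compound 2 to compound 3 (0.51 log units; beyond the scatter), in which a group joined through oxygen on the same saturated ring carbon gave way to benzylcarbamoyl. Compound 4 goes back to a group joined through oxygen while keeping the six-membered aromatic ring of carbon only, so the values of compound 2 and compound 3 bracket the likely outcome. A modest rise toward the number of compound 2 is expected, though a result within the scatter would not surprise. The step expected is a 2.4-fold higher number from compound 3 to compound 4 (0.38 log units; beyond the scatter). Compound 4 is expected to give 12 nM in this assay, within a range from 4 nM to 40 nM.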

Compound 4, half-maximal effective concentration: 3 nM
Estimate against measurement, compound 4: 4.0-fold (0.60 log units) above; the measured number lies below the stated range.
By their numbers in this assay, from the lowest: compounds 4 and 3 (each within the scatter of the next); then compound 2; then compound 1.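

In this assay, the step from benzylcarbamoyl to phenethyloxy on the saturated ring carbon is a 1.7-fold lower number from compound 3 to compound 4 (0.22 log units; within the scatter), so the carbonyl and the amide hydrogen of benzylcarbamoyl can be given up here without a step beyond the scatter. The earlier step from compound 2 to compound 3 had changed the group joined to the ring carbon and the terminal ring at once, whereas keeping the ether chain and replacing only 3,5-dimethyl-1H-pyrazol-1-yl with phenyl gives a 5.3-fold lower number from compound 2 to compound 4 (0.73 log units; beyond the scatter); among these three compounds, the lower numbers therefore go with the phenyl ring, whether it is carried on phenethyloxy or on benzylcarbamoyl. No evidence is available to account for either step.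

The compounds shown do not tell how much the length of the chain matters, since a shorter benzyloxy group or a longer phenylpropoxy chain would be needed to test it. They also leave open whether the phenyl ring tolerates a substituent such as fluorine, methoxy or an amine, or whether a pyridine ring could replace it.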